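The source may report more compounds than this note shows. Statements on the series, on what has been measured and on what is new or still open speak of the compounds shown alone.

Measured compounds and their readings in an assay on HeLa cells for inhibition of Kinesin-like protein KIF15 (Homo sapiens), read by microscopy, with stated times of 2 s and 20 s, tested at 750 nM; on this read-out higher numbers stand for more inhibition at the one concentration tested (going by the name of the read-out) and lower numbers for less inhibition:

Compound 1, `O=C1Nc2ccc(C(=O)c3ccco3)cc2/C1=C/c1cc(F)c(O)c(F)c1`, 21%
Compound 2, `O=C1Nc2ccc(C(=O)c3ccco3)cc2/C1=C/c1cc(Br)c(O)c(Br)c1`, 65%
Compound 3, `O=C1Nc2ccc(C(=O)c3ccco3)cc2/C1=C/c1cc(Cl)c(O)c(Br)c1`, 62%

Compound 2 gives the highest of the three numbers, yet its gap to compound 3 is a number 3 percentage points lower from compound 2 to compound 3 (within the scatter), so the two cannot be ordered. The large steps are a number 44 percentage points higher from compound 1 to compound 2 (beyond the scatter) and a number 41 percentage points higher from compound 1 to compound 3 (beyond the scatter), both of which swap the two fluorines for heavier halogens while keeping the hydroxy group.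

Compound 4 is `COc1c(Br)cc(/C=C2\C(=O)Nc3ccc(C(=O)c4ccco4)cc32)cc1Br`. It differs from compound 2 only in that (methyl in place of hydrogen on an oxygen on an aromatic ring). Within the data shown here, every measured step so far changes a halogen on the aromatic ring; none touches the oxygen that carries the hydroxy group, so no direct comparison speaks to this change. The halogen steps show that the ring bearing the hydroxy group is sensitive to substitution, which argues for caution rather than for a particular direction. The expected step from compound 2 to compound 4 is therefore uncertain and spans a wide range, with a modest fall as the middle guess: a number 25 percentage points lower from compound 2 to compound 4 (beyond the scatter). On that basis compound 4 is estimated at 40%, expected to fall between 10% and 70%.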

Compound 4, a percentage reported as inhibition, at one concentration (the size of the read-out at that concentration, not a potency): -12.6%
Compound 4: middle estimate off by 52.6 percentage points, on the high side; the whole stated range lies above it.
By their numbers in this assay, from the lowest: compound 4; then compound 1; then compounds 3 and 2 (each within the scatter of the next).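

In this assay, among these compounds, the step to the methoxy compound is a number 77.6 percentage points lower from compound 2 to compound 4 (beyond the scatter), so the hydroxy group on this ring matters for the reading, and the first change at this oxygen removes the inhibition seen with compound 2. Both bromines stay in place, yet compound 4 gives -12.6%, a reading on the negative side; the two bromines that accompany the high number of compound 2 are therefore not enough on their own, and a free hydroxy hydrogen goes with activity in this pair. No measurement here explains why adding one methyl has so large an effect.

Among the compounds shown, this oxygen carries only a hydrogen or a methyl, so it remains open whether a longer chain such as ethyl, or an amine in place of the hydroxy, would keep any of the reading of compound 2. As far as these compounds go, it is also open whether the same change would have a similar effect with other halogens on the ring, such as the two fluorines of compound 1 or the chlorine and bromine of compound 3.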